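The source may hold more compounds than are shown below. What is called first, only, known or untested is meant among the compounds shown, and "the series" means these compounds.

Compound 2 `O=C(NCc1ccccc1)c1c(O)c2cccnc2n(-c2ccccc2)c1=O` is the lower of the two compounds measured in a functional assay on the whole organism for inhibition, with Rattus norvegicus as the target, read by paw edema, at a dose of 100 mg/kg by the oral route; on this read-out higher numbers stand for more inhibition at the one dose given (going by the name of the read-out) and lower numbers for less inhibition: in this assay compound 2 gives 1.6%, while compound 1 `CCOC(=O)c1c(O)c2cccnc2n(-c2ccccc2)c1=O` gives 23.5%, a move of a number 21.9 percentage points lower from compound 1 to compound 2 (beyond the scatter). Compound 3 `CN(C)CCNC(=O)c1c(O)c2cccnc2n(-c2ccccc2)c1=O` differs from compound 2 by (dimethylamino)methyl in place of phenyl on a saturated chain carbon bound to an amide-type nitrogen. Among the measured compounds shown here, no measured step touches this part of the structure, since the only step known concerns the carbonyl substituent, so no size can be read across from it. Compound 3 is therefore expected to give about 12%, between 0% and 35%, an estimated step of a number 10.4 percentage points higher from compound 2 to compound 3 (beyond the scatter) that may not exceed the scatter.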

Compound 3, a percentage reported as inhibition, in the whole organism at one dose (the size of the read-out at that dose, not a potency): 22.6%
The estimate for compound 3 lay 10.6 percentage points below the measured number, and the stated range covers the measured number.
By their numbers in this assay, from the lowest: compound 2; then compounds 3 and 1 (each within the scatter of the next).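

Replacing benzyl with 2-(dimethylamino)ethyl on the amide-type nitrogen gives a number 21 percentage points higher from compound 2 to compound 3 (beyond the scatter), so the low number of compound 2 does not hold for every amide and depends on the group carried by that nitrogen. Replacing ethoxy with (2-(dimethylamino)ethyl)amino on the carbonyl carbon gives a number 0.9 percentage points lower from compound 1 to compound 3 (within the scatter), so these two compounds cannot be told apart in this assay. No evidence is available that explains this difference.

The compounds shown do not separate the departure of the phenyl ring from the arrival of the dimethylamino group. From the compounds shown here alone, whether a longer chain carrying dimethylamino, or a piperidine in its place, would give a similar number remains open.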